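This account rests on a few compounds, and the source may have more. Where it says the series, first, only, none or still open, it means among the compounds named here.

In a functional assay on the whole organism (strain Sprague-Dawley) for inhibition, with Rattus norvegicus as the target, with a stated time of 10 min (a higher number here means that more compound is needed for the effect, a lower number that less compound is needed), three compounds sharing one core have been measured. Compound 1 `CC(C)Oc1ccccc1-c1ncc(C(=O)O)c(=O)[nH]1` gives 0.8 mg/kg, compound 2 `CC(C)COc1ccccc1-c1ncc(C(=O)O)c(=O)[nH]1` gives 0.5 mg/kg, and compound 3 `O=C(O)c1cnc(-c2ccccc2OCc2ccccc2)[nH]c1=O` gives 5 mg/kg, the highest number of the three. The next structure, compound 4 `C[S+]([O-])c1ccccc1-c1ncc(C(=O)O)c(=O)[nH]1`, changes compound 3 at the benzyloxy group: a group of 3 heavy atoms (1 carbon, 1 oxygen, 1 sulfur; no ring) in place of a group of 8 heavy atoms (7 carbon, 1 oxygen; one six-membered aromatic ring of carbon only), on an aromatic carbon. Within the data shown here, no measured compound carries the entering group, so the evidence is indirect. Placing benzyl where isopropyl stood gave a 6.3-fold higher number from compound 1 to compound 3 (0.80 log units; beyond the scatter), and the comparison with the isobutyl ether, a 10-fold higher number from compound 2 to compound 3 (1.00 log units; beyond the scatter), points the same way, both steps being modest. The isopropyl and isobutyl ethers themselves differ only by a 1.6-fold lower number from compound 1 to compound 2 (0.20 log units; within the scatter), which lies within the scatter. Removing the benzyloxy group may therefore lower the number, but the entering group is not an ether and need not reach the values of those two compounds. The expected step, a 1.7-fold lower number from compound 3 to compound 4 (0.22 log units; within the scatter), is a small fall that stays within the scatter. For compound 4 the estimated value is 3 mg/kg, with an expected range from 0.7 mg/kg to 12 mg/kg.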

Compound 4, dose for 50% inhibition: > 5 mg/kg
Compound 4: no number, only a limit; the forecaster's own chance of this, stated with the estimate: 15%; middle value at least 1.6-fold (0.22 log units) from the limit.
By their numbers in this assay, from the lowest: compounds 2 and 1 (each within the scatter of the next); then compound 3.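

Compound 4 gives only a limit in this assay, not a number: the limit of > 5 mg/kg in this assay, at which 1 of the 4 values shown sits. There is a number no lower from compound 3 to compound 4 (the limit leaves the size open), so how far this sulfur group stands from benzyloxy stays undecided, but the comparison with the two smaller ethers can be read: there is an at least 10-fold higher number from compound 2 to compound 4 (1.00 log units; beyond the scatter), and an at least 6.2-fold higher number from compound 1 to compound 4 (0.79 log units; beyond the scatter). At this aromatic carbon, therefore, a group with fewer heavy atoms than benzyloxy does not by that alone return the number to the level of the isopropyl and isobutyl ethers.

The compounds shown leave open what number lies behind the limit of compound 4. They also leave open whether an oxygen bound directly to the aromatic carbon matters, which a methyl thioether, a sulfone, an amine or a longer ether chain in this place could test.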